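The compounds below may be only part of what the source reports. "The series", "measured", "known", "first", "only" and "open" are said of these compounds alone.

In an ADME assay on MT4 cells (Homo sapiens) for cytotoxicity, read by MTT assay, with a stated time of 96 h (a lower number here means that less compound is tolerated, a higher number that more compound is tolerated), compound 2 `O=C(CCl)Nc1ccc(-c2nc3cc(C(F)(F)F)ccc3[nH]2)cc1` gives 5000 nM, the lower of the two measured numbers. Compound 1 `O=C(CN1CCCC1)Nc1ccc(-c2nc3ccccc3[nH]2)cc1` gives 40000 nM in this assay, a gap beyond the usual scatter. Compound 3 `O=C(CN1CCCC1)Nc1ccc(-c2nc3cc(C(F)(F)F)ccc3[nH]2)cc1` arises from compound 2 by a single change: pyrrolidin-1-yl in place of chloro on a saturated chain carbon bound to a carbonyl carbon. Compound 1 already carries that pyrrolidin-1-yl group on the same chain. An upward step, toward more compound being tolerated, is therefore expected, a 5.0-fold higher number from compound 2 to compound 3 (0.70 log units; beyond the scatter), because compound 1 gives 40000 nM with the pyrrolidin-1-yl group in place. Compound 3 is estimated at 25000 nM, most likely between 8000 nM and 60000 nM.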

Compound 3, half-maximal cytotoxic concentration: 18000 nM
For compound 3 the middle estimate is 1.4-fold (0.14 log units) above the measured one; the measured number falls inside the stated range.
By their numbers in this assay, from the lowest: compound 2; then compound 3; then compound 1.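

With the trifluoromethyl group on the core, pyrrolidin-1-yl in place of chloro on a saturated chain carbon bound to a carbonyl carbon gives a 3.6-fold higher number from compound 2 to compound 3 (0.56 log units; beyond the scatter) in this assay and so lets more compound be tolerated. With pyrrolidin-1-yl held fixed, trifluoromethyl in place of hydrogen on an aromatic carbon gives a 2.2-fold lower number from compound 1 to compound 3 (0.35 log units; beyond the scatter) and so moves the number the other way. No supporting measurement explains either step. Still open, going by these compounds, is how another amine, such as morpholine, or a longer chain carrying the pyrrolidin-1-yl group would compare.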